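Shortening the chain on a stilbene-chalcone hybrid

This account rests on a few compounds, and the source may have more. Where it says the series, first, only, none or still open, it means among the compounds named here.

Compound 1 `CCCCCCOc1ccc(C(=O)/C=C/c2c(/C=C/c3ccc(OC)cc3)cc(OC)cc2OC)cc1` was tested in a functional assay on B16-F10 cells (Mus musculus) for antiproliferative activity, read by MTT assay, with a stated time of 48 h (on this read-out higher numbers stand for weaker inhibition and lower numbers for stronger inhibition), where compound 1 gave 10.4 ug/mL. Two relatives share its core: compound 2 `COc1ccc(/C=C/c2cc(OC)cc(OC)c2/C=C/C(=O)c2ccc(Cl)c(Cl)c2)cc1` gave 7.5 ug/mL, and compound 3 `CCCC(C)Oc1ccc(C(=O)/C=C/c2c(/C=C/c3ccc(OC)cc3)cc(OC)cc2OC)cc1` gave 6.7 ug/mL. Compound 1 carries the highest of these three numbers, yet its gaps to compound 2 and compound 3 are both within the scatter. Compound 4 `COc1ccc(/C=C/c2cc(OC)cc(OC)c2/C=C/C(=O)c2ccc(OC)cc2)cc1` is not yet measured; it differs from compound 1 by hydrogen in place of pentyl on a saturated chain carbon bound to an oxygen on an aromatic ring. The step of a 1.6-fold lower number from compound 1 to compound 3 (0.19 log units; within the scatter) also alters only the chain on the aromatic oxygen and stays within the scatter, and a 1.1-fold lower number from compound 2 to compound 3 (0.05 log units; within the scatter) likewise stays within it. So compound 4 is expected to give 9 ug/mL (range 4 ug/mL to 20 ug/mL), a step of a 1.2-fold lower number from compound 1 to compound 4 (0.06 log units; within the scatter).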

Compound 4, half-maximal inhibitory concentration: 5.8 ug/mL
The estimate for compound 4 lay 1.6-fold (0.19 log units) above the measured number; measured number inside the range.
By their numbers in this assay, from the lowest: compounds 4, 3, 2 and 1 (each within the scatter of the next).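

Cutting hexyloxy down to methoxy removes the whole pentyl part of the chain, yet the number in this assay stays within the scatter (a 1.8-fold lower number from compound 1 to compound 4 (0.25 log units; within the scatter)). The same holds for methyl in place of branched 1-methylbutyl (a 1.2-fold lower number from compound 3 to compound 4 (0.06 log units; within the scatter)) and for 4-methoxyphenyl in place of 3,4-dichlorophenyl (a 1.3-fold lower number from compound 2 to compound 4 (0.11 log units; within the scatter)), so among these four compounds neither the length nor the branching of the chain on this oxygen separates them. No supporting measurement bears on this result. Going by these compounds, whether a chain longer than hexyl, or an amine or carboxylic acid carried on that chain, would move the number beyond the scatter remains open.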